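The compounds below may be only part of what the source reports. "The series", "measured", "known", "first", "only" and "open" are said of these compounds alone.

Compound 1, `CC(C)c1nc(C(C)(C)C)cc(-c2ccc(F)cc2)c1/C=C/[C@@H]1C[C@@H](O)CC(=O)O1`, gives 1 nM in an assay for inhibition of 3-hydroxy-3-methylglutaryl-coenzyme A reductase (Rattus norvegicus); on this read-out higher numbers stand for weaker inhibition and lower numbers for stronger inhibition.
Compound 2, `CC(C)c1nc(C2CCCCC2)cc(-c2ccc(F)cc2)c1/C=C/[C@@H]1C[C@@H](O)CC(=O)O1`, gives 4 nM in this assay.
Compound 3, `CC(C)c1nc(-c2ccc(F)cc2)cc(-c2ccc(F)cc2)c1/C=C/[C@@H]1C[C@@H](O)CC(=O)O1`, gives 2 nM in this assay.

Among these three numbers compound 3 holds the second highest place. Its nearest neighbour is compound 1, with a 2.0-fold higher number from compound 1 to compound 3 (0.30 log units; within the scatter), and the furthest is compound 2, with a 2.0-fold lower number from compound 2 to compound 3 (0.30 log units; within the scatter); both of these steps lie within the scatter, so the three compounds cannot be ordered on these numbers.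

Compound 4, `Cc1cc(C)cc(-c2cc(-c3ccc(F)cc3)c(/C=C/[C@@H]3C[C@@H](O)CC(=O)O3)c(C(C)C)n2)c1`, is not yet measured. It differs from compound 3 in one place: 3,5-dimethylphenyl in place of 4-fluorophenyl on an aromatic carbon. The measured steps that bear on this change are the two that alter the same aromatic carbon, a 2.0-fold higher number from compound 1 to compound 3 (0.30 log units; within the scatter) and a 4.0-fold higher number from compound 1 to compound 2 (0.60 log units; beyond the scatter). Of these only the second went beyond the scatter, and even that step was modest. Within the data shown here, the group that enters in compound 4 is not present in any measured compound, so no step shows it directly.

On this basis compound 4 is expected to sit close to compound 3 in this assay, with a step of a 1.5-fold higher number from compound 3 to compound 4 (0.18 log units; within the scatter) that is expected to stay within the scatter. Compound 4 is therefore estimated at 3 nM, with a range from 1 nM to 10 nM.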

Compound 4, half-maximal inhibitory concentration: 8 nM
Compound 4: middle estimate off by 2.7-fold (0.43 log units), on the low side; the range from low to high includes it.
By their numbers in this assay, from the lowest: compounds 1, 3, 2 and 4 (each within the scatter of the next, the first and the last beyond it).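

In this assay, among these compounds, the change from 4-fluorophenyl to 3,5-dimethylphenyl gives a 4.0-fold higher number from compound 3 to compound 4 (0.60 log units; beyond the scatter), the first step beyond the scatter between two aromatic groups on this carbon next to the ring nitrogen, so an aromatic ring here does not by itself settle the reading. Among the compounds shown here, the largest step at this position so far is an 8.0-fold higher number from compound 1 to compound 4 (0.90 log units; beyond the scatter), which widens the span seen among the tert-butyl, cyclohexyl and 4-fluorophenyl compounds, while a 2.0-fold higher number from compound 2 to compound 4 (0.30 log units; within the scatter) leaves 3,5-dimethylphenyl and cyclohexyl indistinguishable on these numbers. Nothing available accounts for the size of these steps.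

The compounds shown leave open whether the step away from compound 3 goes with the arrival of the methyl groups or with the loss of the fluorine, a question that a plain phenyl or a 4-methylphenyl on this carbon would address. They also leave open how this position would read with an amine, a carboxylic acid or a longer alkyl chain in place of these hydrocarbon and fluorophenyl groups.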